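The source may hold more compounds than are shown below. What is called first, only, known or untested is meant among the compounds shown, and "the series" means these compounds.

Measured compounds:
compound 1 `Cc1ccc2c(c1)CCCN2c1nc(Cl)nc2ccccc12` gives 48 nM in a functional assay on KB cells (Homo sapiens) for cytotoxicity, read by sulforhodamine B assay; a lower number here means a stronger inhibitor of growth, a higher number a weaker inhibitor of growth;
compound 2 `Cc1ccc2c(c1)CCCN2c1nc(C)nc2ccccc12` gives 204 nM;
compound 3 `COc1ccc2c(c1)CCCCN2c1nc(Cl)nc2ccccc12` gives 227 nM.

Compound 4 `COc1ccc2c(c1)CCCCN2c1nc(C)nc2ccccc12` has not yet been measured. Its relation to compound 3 is the change (methyl in place of chloro on an aromatic carbon), and the same change is already on record between two measured compounds, as methyl in place of chloro on an aromatic carbon. That step gave a 4.3-fold higher number from compound 1 to compound 2 (0.63 log units; beyond the scatter), a clear weakening in this assay. How the core of compound 3 differs from the core of compound 1 is not broken down here; compound 3 simply stands with the highest number of the three, near compound 2 and well apart from compound 1. Because the same change gave a 4.3-fold higher number from compound 1 to compound 2 (0.63 log units; beyond the scatter), a step of similar size is expected for compound 4, namely a 4.2-fold higher number from compound 3 to compound 4 (0.62 log units; beyond the scatter). Compound 4 is therefore estimated at 950 nM, within a range from 400 nM to 2500 nM.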

Compound 4, concentration for 50% growth inhibition: 19 nM
Compound 4: the middle estimate sits 50-fold (1.70 log units) above what was measured; the whole stated range lies above it.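

In this assay, methyl in place of chloro between the two ring nitrogen atoms gave a 12-fold lower number from compound 3 to compound 4 (1.08 log units; beyond the scatter), a shift in the opposite direction to the earlier step on the other core. The two steps disagree, so in this series the change cannot be carried from one core to another as a fixed shift: the same change on two cores in this assay, a 4.3-fold higher number (0.63 log units; beyond the scatter) from compound 1 to compound 2 and a 12-fold lower number (1.08 log units; beyond the scatter) from compound 3 to compound 4, 51-fold (1.71 log units) apart, beyond the scatter of two such steps. This shows that the outcome of the change differs between these two cores, but it does not show which feature of the cores accounts for that, or how the change would run on any further core.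

The compounds shown leave open how other groups in this place, such as an amine or a nitrile, would behave on either core. They also leave open what each separate difference between the two cores contributes, as those cores differ in more than one place.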